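Para-substituted phenyl replaces naphthyl on the shared core

The source may hold more compounds than are shown below. What is called first, only, known or untested is meant among the compounds shown, and "the series" means these compounds.

Compound 3 `c1ccc2c(-c3cn4ccnc4c(-c4ccc5ncn(C6CCCCC6)c5c4)n3)cccc2c1` holds the lowest of the three numbers in a functional assay on SR cells (Homo sapiens) for inhibition, read by sulforhodamine B assay, with a stated time of 48 h, tested at 10 uM (a higher number here means more inhibition at the concentration tested (going by the name of the read-out), a lower number less inhibition), where compound 3 gives 6.92%. Its nearest neighbour is compound 1 `c1ccc(-c2cn3ccnc3c(-c3ccc4ncn(C5CCCCC5)c4c3)n2)cc1`, which in this assay gives 59.8%; the step of a number 52.9 percentage points lower from compound 1 to compound 3 (beyond the scatter) put naphthalen-1-yl in place of phenyl on an aromatic carbon. Furthest is compound 2 `COc1ccc(-c2cn3ccnc3c(-c3ccc4ncn(C5CCCCC5)c4c3)n2)cc1`, which in this assay gives 91.7%; the step of a number 84.8 percentage points lower from compound 2 to compound 3 (beyond the scatter) put naphthalen-1-yl in place of 4-methoxyphenyl. Both steps are large and both run downward on arrival at compound 3. The remaining step of a number 31.9 percentage points higher from compound 1 to compound 2 (beyond the scatter) shows methoxy in place of hydrogen on an aromatic carbon raising the number markedly.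

Compound 4 `CC(=O)c1ccc(-c2cn3ccnc3c(-c3ccc4ncn(C5CCCCC5)c4c3)n2)cc1` has not yet been measured. The change from compound 3 is 4-acetylphenyl in place of naphthalen-1-yl on an aromatic carbon. This removes the group that both downward steps introduced and again brings one six-membered aromatic ring of carbon only, bearing a single substituent, as in compound 2. Because of a number 52.9 percentage points lower from compound 1 to compound 3 (beyond the scatter) and a number 84.8 percentage points lower from compound 2 to compound 3 (beyond the scatter) a large upward step is expected in this assay; whether acetyl carries as far as methoxy did in compound 2 cannot be read from three compounds, so the range is wide. The step is estimated as a number 58.1 percentage points higher from compound 3 to compound 4 (beyond the scatter). For compound 4 the expected value is 65%, with a range from 35% to 92%.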

Compound 4, a percentage reported as inhibition, at one concentration (the size of the read-out at that concentration, not a potency): 23.6%
Estimate against measurement, compound 4: 41.4 percentage points above; the measured number lies below the stated range.
By their numbers in this assay, from the lowest: compound 3; then compound 4; then compound 1; then compound 2.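

Working notes: at this position, a single six-membered aromatic ring of carbon only does not by itself restore the number in this assay, since the step of a number 16.7 percentage points higher from compound 3 to compound 4 (beyond the scatter) is only modest and compound 4 remains the second lowest of the four. What separates the compounds with this ring is the substituent on it: the step of a number 68.1 percentage points lower from compound 2 to compound 4 (beyond the scatter) for acetyl in place of methoxy and the step of a number 36.2 percentage points lower from compound 1 to compound 4 (beyond the scatter) for acetyl in place of hydrogen show that acetyl and methoxy move the number in opposite directions from compound 1, with acetyl ending much nearer to the naphthalen-1-yl compound than to the methoxy compound. Nothing at hand bears on why these two substituents part in this way.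

The compounds shown leave open how a hydroxy group, an amine or a carboxylic acid on this phenyl ring would stand against methoxy and acetyl. They also leave open whether the high number of compound 2 carries over to ethoxy or a longer alkoxy chain.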